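Chloro on the Shared Core: Expecting the Cytotoxicity Number

This account rests on a few compounds, and the source may have more. Where it says the series, first, only, none or still open, it means among the compounds named here.

Compound 1, `CC(=O)Oc1ccc2c(c1)C(C)=CC(C)(C)N2Cc1ccccc1`: 18000 nM
Compound 2, `CC(=O)Oc1ccc2c(c1)C(C)=CC(C)(C)N2Cc1ccc(C(C)C)cc1`: 10000 nM

In an ADME assay on L6 cells (Rattus norvegicus) for cytotoxicity, read by resazurin assay, with a stated time of 70 h (a higher number here means a weaker inhibitor, a lower number a stronger inhibitor), compound 1 gives 18000 nM, the higher of the two numbers. Compound 2 gives 10000 nM in this assay. Within the data shown here, the only step measured, a 1.8-fold lower number from compound 1 to compound 2 (0.26 log units; within the scatter), stays within the scatter. Compound 3, `CC(=O)Oc1cc2c(cc1Cl)N(Cc1ccccc1)C(C)(C)C=C2C`, differs from compound 1 by chloro in place of hydrogen on an aromatic carbon. That one measured step alters a different aromatic carbon, so nothing measured speaks to a chloro at this place. No step beyond the scatter is therefore expected, and no change at the digits printed from compound 1 to compound 3 (within the scatter) is the estimated step. Compound 3 is expected at 18000 nM, between 7000 nM and 45000 nM.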

Compound 3, half-maximal inhibitory concentration: 22000 nM
Beside the measured number, compound 3's estimate is 1.2-fold (0.09 log units) below it, and the stated range covers the measured number.
By their numbers in this assay, from the lowest: compounds 2, 1 and 3 (each within the scatter of the next, the first and the last beyond it).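

In this assay, among these compounds, chloro on this aromatic carbon, ortho to an acetoxy group, gives a 1.2-fold higher number from compound 1 to compound 3 (0.09 log units; within the scatter) and so offers the first reading at this position of the shared core. A single chlorine atom in place of hydrogen here leaves the number within the usual scatter. Nothing measured on these compounds offers an explanation for this result. As far as these compounds go, whether an amine or a carboxylic acid at this same carbon would move the number beyond the scatter remains open. So does the outcome of combining this chloro with the isopropyl of compound 2.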